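Bromo in place of benzyloxy on the pendant ring

A few compounds are considered here, and "the series" means these few. Any claim that something is new, unique, unknown or untested is made for them only; others in the source may bear on it.

Three analogues on a shared core have been measured. Compound 1 `Cc1cc(O)c(C(=O)/C=C/c2cccc3ccccc23)c(-c2ccccc2)c1C(=O)/C=C/c1cccc2ccccc12` gives 30000 nM in a functional assay on MCF7 cells (Homo sapiens) for cytotoxicity, read by MTT assay, with a stated time of 24 h; a lower number here means a stronger inhibitor, a higher number a weaker inhibitor. Compound 2 `Cc1cc(O)c(C(=O)/C=C/c2ccc(Br)cc2)c(-c2ccc(OCc3ccccc3)cc2)c1C(=O)/C=C/c1ccc(Br)cc1` gives 30000 nM in this assay, level with compound 1 at the digits shown and together the highest of the three numbers. Compound 3 `Cc1cc(O)c(C(=O)/C=C/c2ccc(OCc3ccccc3)cc2)c(-c2ccc(OCc3ccccc3)cc2)c1C(=O)/C=C/c1ccc(OCc2ccccc2)cc1` gives 26000 nM in this assay, a gap to compound 2 that lies within the scatter. Compound 4 `Cc1cc(O)c(C(=O)/C=C/c2ccc(Br)cc2)c(-c2ccc(Br)cc2)c1C(=O)/C=C/c1ccc(Br)cc1` is not yet measured; it differs from compound 2 by bromo in place of benzyloxy on an aromatic carbon. Within the data shown here, no step between measured compounds is available to size this change. Since all three numbers sit close together at weak inhibition, the step of no change at the digits printed from compound 2 to compound 4 (within the scatter) is expected to stay within the scatter. Compound 4 is estimated at 30000 nM, with a range from 12000 nM to 75000 nM.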

Compound 4, half-maximal inhibitory concentration: 15000 nM
Beside the measured number, compound 4's estimate is 2.0-fold (0.30 log units) above it; the range from low to high includes it.
By their numbers in this assay, from the lowest: compounds 4, 3, 1 and 2 (each within the scatter of the next).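

In this assay, among these compounds, bromo in place of benzyloxy gives a 2.0-fold lower number from compound 2 to compound 4 (0.30 log units; within the scatter) and is the first sized step at this position. On an aromatic carbon para to a large group, the benzyloxy, with its six-membered aromatic ring and hydrogen-bond acceptor, can thus give way to bromo, which has neither, with the step staying within the scatter. No measured evidence bears on this result. Open, going by these compounds, is whether an amine or a carboxylic acid at this position would give a step beyond the scatter.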